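Trading Nitro for Methyl on Compound 1

A few compounds are considered here, and "the series" means these few. Any claim that something is new, unique, unknown or untested is made for them only; others in the source may bear on it.

Among the measured compounds shown here, in a functional assay on HCT-116 cells (Homo sapiens) for inhibition, read by MTT assay, with a stated time of 48 h (on this read-out lower numbers stand for stronger inhibition and higher numbers for weaker inhibition), compound 1 `C/C=C/C(=O)N(Cc1ccc(OC)c([N+](=O)[O-])c1)c1cc(OC)c(OC)c(OC)c1` gives 670 nM, the highest number of the three compounds measured so far. The other two are compound 2 `C#CC(=O)N(Cc1ccc(OC)c(O)c1)c1cc(OC)c(OC)c(OC)c1` at 310 nM and compound 3 `C/C=C/C=C/C(=O)N(Cc1ccc(OC)c(O)c1)c1cc(OC)c(OC)c(OC)c1` at 180 nM.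

The next compound, compound 4 `C/C=C/C(=O)N(Cc1ccc(OC)c(C)c1)c1cc(OC)c(OC)c(OC)c1`, differs from compound 1 in one place only: methyl in place of nitro on an aromatic carbon. This is methyl in place of nitro on an aromatic carbon, ortho to a methoxy group.

For the measured compounds named here, the only measured step is a 1.7-fold lower number from compound 2 to compound 3 (0.24 log units; within the scatter). It puts penta-1,3-dien-1-yl in place of ethynyl on a carbonyl carbon, a different part of the molecule, and it stays within the scatter. Neither compound 2 nor compound 3 differs from compound 1 in just one place, so no measurement isolates this swap. No step beyond the scatter can therefore be expected with confidence, only a slight lean towards a lower number, since compound 1 stands at the top of this small set with 670 nM. The expected change is a 1.5-fold lower number from compound 1 to compound 4 (0.17 log units; within the scatter). For compound 4 the estimate is 450 nM, with an expected range from 130 nM to 1500 nM.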

Compound 4, half-maximal inhibitory concentration: 23500 nM
The estimate for compound 4 lay 52-fold (1.72 log units) below the measured number; measured number above the stated range.
By their numbers in this assay, from the lowest: compounds 3 and 2 (each within the scatter of the next); then compound 1; then compound 4.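

With everything else in the molecule held constant, putting methyl in place of nitro on this aromatic carbon, ortho to a methoxy group, gives a 35-fold higher number from compound 1 to compound 4 (1.54 log units; beyond the scatter) in this assay and so shows that inhibition of these cells depends strongly on the group at this one position. The earlier step, a 1.7-fold lower number from compound 2 to compound 3 (0.24 log units; within the scatter), changed the group on the carbonyl carbon and stayed within the scatter, so it gave no sign that a single change could matter this much. The change takes away nitro, with its 3 heavy atoms and 2 hydrogen-bond acceptors, and brings in methyl, with 1 heavy atom and no hydrogen-bond acceptors, but no measurement available here says which of these differences matters or explains the size of the step.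

The compounds shown leave open how other groups on this same carbon, such as an amine or a nitrile, would compare with nitro and methyl. They also leave open whether this swap would have a similar effect with ethynyl or penta-1,3-dien-1-yl on the carbonyl carbon in place of the group shared by compound 1 and compound 4.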